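Amide variation in a weakly antiproliferative series

The source may hold more compounds than are shown below. What is called first, only, known or untested is meant among the compounds shown, and "the series" means these compounds.

Going by the values given here, compound 3 `Cn1cc(-c2nn(Cc3ccc(C(=O)N4CCCCC4)cc3)c(=O)c3ccccc23)cn1` is the only member of the set that gives a number in a functional assay on HeLa cells (Homo sapiens) for antiproliferative activity, read by MTT assay, with a stated time of 72 h; a lower number here means a stronger inhibitor, a higher number a weaker inhibitor; in this assay compound 3 gives 65500 nM. Compound 1 `Cc1noc(C)c1-c1nn(Cc2ccc(C(=O)NC3CCCCC3)cc2)c(=O)c2ccccc12` reaches only the limit of this assay, > 100000 nM. Compound 2 `Cc1noc(C)c1-c1nn(Cc2ccc(C(=O)N3CCCCC3)cc2)c(=O)c2ccccc12` likewise reaches only the limit, > 100000 nM. The step that the two limits leave unreadable from compound 1 to compound 2 therefore cannot be read, which follows from the limit of > 100000 nM in this assay, at which 2 of the 3 values shown sit. The step of an at least 1.5-fold lower number from compound 2 to compound 3 (0.18 log units; that floor lies within the scatter) is the only readable one, and its floor lies within the scatter.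

Compound 4 `Cn1cc(-c2nn(Cc3ccc(C(=O)NC4CC(C)(C)N([O])C(C)(C)C4)cc3)c(=O)c3ccccc23)cn1` differs from compound 3 at the amide: a group of 12 heavy atoms (9 carbon, 2 nitrogen, 1 oxygen; one six-membered non-aromatic ring with 1 hetero atom) in place of a group of 6 heavy atoms (5 carbon, 1 nitrogen; one six-membered non-aromatic ring with 1 hetero atom), on a carbonyl carbon. Among the compounds with values here, the only measured step at this position is a step that the two limits leave unreadable from compound 1 to compound 2, which is unreadable, so no measured step gives a size or direction to carry over to the present change. Compound 4 is expected to give about 65000 nM in this assay, with a range of 20000 nM to 200000 nM. The expected step of a 1.0-fold lower number from compound 3 to compound 4 (0.00 log units; within the scatter) is thus none beyond the scatter, with a fair chance that compound 4 returns only the limit of this assay.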

Compound 4, half-maximal inhibitory concentration: 27700 nM
Estimate against measurement, compound 4: 2.3-fold (0.37 log units) above; measured number inside the range.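

Going by these compounds alone, at the carbonyl carbon, the larger group gives a 2.4-fold lower number from compound 3 to compound 4 (0.37 log units; beyond the scatter) in this assay, the first readable step at this position. The earlier step at this position cannot be read: the limit of > 100000 nM in this assay, at which 2 of the 4 values shown sit. The change brings in a hydrogen-bond donor and a hydrogen-bond acceptor along with the extra heavy atoms, and these compounds do not show which of these features goes with the step.

Still open, on these data alone, is whether the oxygen on the ring nitrogen of the entering group matters, which a plain secondary amine at that ring nitrogen, or an unsubstituted piperidin-4-ylamino group, would test on the same core. As far as these compounds go, it is also open whether the same amide gives a readable number with 3,5-dimethyl-1,2-oxazol-4-yl in place of 1-methyl-1H-pyrazol-4-yl.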